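The source may report more compounds than this note shows. Statements on the series, on what has been measured and on what is new or still open speak of the compounds shown alone.

In a functional assay on MCF7 cells (Homo sapiens) for antiproliferative activity, read by MTT assay, with a stated time of 72 h (on this read-out lower numbers stand for stronger inhibition and higher numbers for weaker inhibition), compound 1 (`CNc1nc(-c2cc(OC)c(OC)c(OC)c2)c(-c2ccc(C)cc2)s1`) gives 10.1 nM as a measured value. Compound 2 (`COc1cc(-c2nc(N(C)C)sc2-c2ccc(C)cc2)cc(OC)c1OC`) gives > 10000 nM as a limit of the assay and not a number, and so stands only at the limit of > 10000 nM in this assay, at which 1 of the 2 values shown sits, on the numbers shown. Compound 3 (`COc1cc(-c2nc(C)sc2-c2ccc(C)cc2)cc(OC)c1OC`) has methyl in place of dimethylamino on an aromatic carbon and is still to be measured. For the measured compounds named here, one measured step bears on this change: an at least 990-fold higher number from compound 1 to compound 2 (2.99 log units; beyond the scatter) with methyl in place of hydrogen on a nitrogen on an aromatic ring. That nitrogen is the one that leaves with the dimethylamino group, so the large step shows how much this place can move the read-out. Going by the values given here, the step gives only indirect guidance, as no compound with methyl here has been measured. A large step towards a lower number is therefore expected, though probably not all the way back to the value of compound 1. The estimated change is an at least 20-fold lower number from compound 2 to compound 3 (1.30 log units; beyond the scatter) in this assay as the working expectation. Compound 3 is estimated at 500 nM with 40 nM to 8000 nM as the expected range.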

Compound 3, half-maximal inhibitory concentration: 1740 nM
Beside the measured number, compound 3's estimate is 3.5-fold (0.54 log units) below it; measured number inside the range.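

In this assay, a group with no nitrogen at this place on the five-membered aromatic ring still gives a measured value: methyl in place of dimethylamino gives an at least 5.7-fold lower number from compound 2 to compound 3 (0.75 log units; beyond the scatter). The size of that step is open at one end, with compound 2 standing only at a limit of the assay: the limit of > 10000 nM in this assay, at which 1 of the 3 values shown sits. Methyl is still far from equal to methylamino at this place, with a 170-fold higher number from compound 1 to compound 3 (2.24 log units; beyond the scatter), so among the three groups shown here, only methylamino, the one group that keeps a hydrogen on the nitrogen, goes with the low number of compound 1.

The compounds shown leave open whether that low number depends on the hydrogen on the nitrogen itself or on the particular size of the methylamino group, and a free amine or an ethylamino group at this place would separate the two. They also leave open whether a group without nitrogen that carries such a hydrogen, such as hydroxyl, would behave like methylamino or like methyl.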